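Swapping the Thioether Arm for a Piperazinyl Enamine

A few compounds are considered here, and "the series" means these few. Any claim that something is new, unique, unknown or untested is made for them only; others in the source may bear on it.

Measured compounds in a functional assay on MCF7 cells (Homo sapiens) for cytotoxicity, read by MTT assay, with a stated time of 24 h, tested at 16 ug/mL; on this read-out lower numbers stand for a weaker effect and higher numbers for a stronger effect at the one concentration tested:
compound 1 `Cn1c(-c2ccc(NC(=O)CSc3nc4cc(Cl)ccc4o3)cc2)nc(-c2ccccc2)c1-c1ccccc1` gives 40%
compound 2 `Cc1ccc2oc(SCC(=O)Nc3ccc(-c4nc(-c5ccccc5)c(-c5ccccc5)n4C)cc3)nc2c1` gives 40.3%
compound 3 `Cn1ccnc1SCC(=O)Nc1ccc(-c2nc(-c3ccccc3)c(-c3ccccc3)n2C)cc1` gives 32.4%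

Compound 3 sits at the low end of the three numbers in this assay, yet the steps of a number 7.6 percentage points lower from compound 1 to compound 3 (within the scatter) and a number 7.9 percentage points lower from compound 2 to compound 3 (within the scatter) both fall within the scatter, so the three compounds cannot be told apart on these data. The step of a number 0.3 percentage points higher from compound 1 to compound 2 (within the scatter) is likewise within the scatter.

Compound 4 `CN(C)/C=C/N1CCN(CC(=O)Nc2ccc(-c3nc(-c4ccccc4)c(-c4ccccc4)n3C)cc2)CC1` is not yet measured. It differs from compound 3 in one place: 4-(2-(dimethylamino)ethenyl)piperazin-1-yl in place of (1-methyl-1H-imidazol-2-yl)sulfanyl on a saturated chain carbon bound to a carbonyl carbon. The two measured steps that touch the same place, from compound 1 to compound 3 and from compound 2 to compound 3, each replaced the group on the sulfur and moved the number only within the scatter. Among the measured compounds shown here, the change to compound 4 is larger than either, since the sulfur itself leaves and a piperazin-1-yl ring enters, so no measured step bears on it directly.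

Compound 4 is therefore expected to give about 30% in this assay, within 12% to 50%. The estimated step of a number 2.4 percentage points lower from compound 3 to compound 4 (within the scatter) is expected to stay within the scatter.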

Compound 4, a percentage reported as activity, at one concentration (the size of the read-out at that concentration, not a potency): 19.4%
Compound 4: middle estimate off by 10.6 percentage points, on the high side; low and high end bracket the measured number.
By their numbers in this assay, from the lowest: compound 4; then compounds 3, 1 and 2 (each within the scatter of the next).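

In this assay the changes to the group on the sulfur stayed within the scatter, but replacing the whole sulfanyl arm with 4-(2-(dimethylamino)ethenyl)piperazin-1-yl on the saturated chain carbon bound to a carbonyl carbon gives a number 13 percentage points lower from compound 3 to compound 4 (beyond the scatter) and a number 20.9 percentage points lower from compound 2 to compound 4 (beyond the scatter) and also a number 20.6 percentage points lower from compound 1 to compound 4 (beyond the scatter) in this series. These modest steps show that the position does respond to a change of this size, and that compound 4 can be told apart from the three thioethers. Nothing measured here explains the drop.

The compounds shown leave open whether the loss of the sulfur, the piperazine ring or the 2-(dimethylamino)ethenyl group accounts for the step. An unsubstituted piperazin-1-yl or a 4-methylpiperazin-1-yl on the same carbon would help separate these parts.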